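The source may hold more compounds than are shown below. What is called first, only, known or untested is meant among the compounds shown, and "the series" means these compounds.

Compound 1 `c1ccc(-c2nc(CNc3nccc(NC4CCCCC4)n3)cs2)cc1` gives 18500 nM
Compound 2 `c1ccc(-c2nc(CNc3nccc(N4CCCC4)n3)cs2)cc1` gives 18300 nM
Compound 3 `c1ccc(-c2nc(CNc3nccc(N4CCCCC4)n3)cs2)cc1` gives 14600 nM

All three were measured in a functional assay on MDA-MB-231 cells (Homo sapiens) for inhibition, read by MTT assay, with a stated time of 72 h (on this read-out higher numbers stand for weaker inhibition and lower numbers for stronger inhibition), and their values lie within the scatter of one another, so compound 3 stands level with both neighbours and no order can be read among them. The next compound, compound 4 `c1ccc(-c2nc(CNc3nccc(N4CCC4)n3)cs2)cc1`, carries azetidin-1-yl in place of piperidin-1-yl on an aromatic carbon and is otherwise unchanged.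

For the measured compounds named here, three measured steps bear on this exchange. The closest is a 1.3-fold lower number from compound 2 to compound 3 (0.10 log units; within the scatter) on going from pyrrolidin-1-yl to piperidin-1-yl. The two others, a 1.0-fold lower number from compound 1 to compound 2 (0.00 log units; within the scatter) and a 1.3-fold lower number from compound 1 to compound 3 (0.10 log units; within the scatter), replace cyclohexylamino. Each lies within the scatter. Going by the values given here, no compound with a four-membered ring has been measured, so this rests on the other three groups alone. No step beyond the scatter is therefore expected in this assay, and the expected change is a 1.2-fold higher number from compound 3 to compound 4 (0.07 log units; within the scatter), which is small and without a firm direction. Compound 4 is estimated at 17000 nM, with an expected range from 9000 nM to 32000 nM.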

Compound 4, half-maximal inhibitory concentration: 27700 nM
For compound 4 the middle estimate is 1.6-fold (0.21 log units) below the measured one, within the range that was stated.
By their numbers in this assay, from the lowest: compounds 3, 2, 1 and 4 (each within the scatter of the next).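

In this assay the azetidin-1-yl group gives a 1.9-fold higher number from compound 3 to compound 4 (0.28 log units; within the scatter) when it replaces piperidin-1-yl, a 1.5-fold higher number from compound 2 to compound 4 (0.18 log units; within the scatter) when it replaces pyrrolidin-1-yl and a 1.5-fold higher number from compound 1 to compound 4 (0.18 log units; within the scatter) when it replaces cyclohexylamino. The position on the aromatic carbon next to the ring nitrogen thus takes a four-membered ring as well as the larger groups without any step beyond the scatter, so ring size among these four groups sets no order. No measurement shown here explains these numbers. On these data alone, what remains open is whether a group with a second hetero atom in the ring, such as morpholine or piperazine, or one with a carboxylic acid on a longer chain, would shift the number at this position beyond the scatter. As far as these compounds go, whether a change elsewhere on the shared core would do so also remains open.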